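Bromo in place of chloro at the assay limit

The source may hold more compounds than are shown below. What is called first, only, known or untested is meant among the compounds shown, and "the series" means these compounds.

In an ADME assay on BJ cells (Homo sapiens) for cytotoxicity, read by luminescence, with a stated time of 72 h (a lower number here means that less compound is needed, a higher number that more compound is needed for the effect), compound 1 `CCOC(=O)c1c(-c2cccc(OC)c2)[nH]c2cc(OC)c(F)cc2c1=O` gives > 21500 nM as a limit and not a number. Compound 2 `CCOC(=O)c1c(-c2cccc(Cl)c2)[nH]c2cc(OC)c(F)cc2c1=O` gives > 21500 nM as a limit too. For the measured compounds named here, the one measured step is a step that the two limits leave unreadable from compound 1 to compound 2 and gives no size to carry forward. What stands so far is the limit of > 21500 nM in this assay, at which 2 of the 2 values shown sit, alone. Going by the values given here, compound 3 `CCOC(=O)c1c(-c2cccc(Br)c2)[nH]c2cc(OC)c(F)cc2c1=O` has bromo in place of chloro on an aromatic carbon as its only difference from compound 2. With no readable step, no shift beyond the scatter is expected in this assay for this change. Estimated here is a step that the limit leaves unreadable from compound 2 to compound 3 as the expected step. For compound 3 the estimate is 25000 nM with an expected range from 15000 nM to 40000 nM and another limit as the likely report.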

Compound 3, half-maximal effective concentration: > 21500 nM
Compound 3: no number, only a limit; the forecaster's own chance of this, stated with the estimate: 85%; the middle value is on the limit's open side.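

No step among compound 1, compound 2 and compound 3 can be read in this assay, each value being a limit and not a number: the limit of > 21500 nM in this assay, at which 3 of the 3 values shown sit.

Left open is whether methoxy, chloro and bromo differ at all in this assay; none of the compounds shown gives a number.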